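This account rests on a few compounds, and the source may have more. Where it says the series, first, only, none or still open, it means among the compounds named here.

Compounds 1, 2 and 3 share one core and differ in the amide or urea arm. Compound 1 `O=C(Nc1cccc(-n2cc(-c3ccncc3)c(-c3ccc(Cl)c(O)c3)n2)c1)Nc1cccc(C(F)(F)F)c1` gives 1340 nM in a functional assay on MCF7 cells (Homo sapiens) for inhibition, read by sulforhodamine B assay, with a stated time of 48 h (a lower number here means a stronger inhibitor of growth, a higher number a weaker inhibitor of growth), compound 2 `COc1cc(-c2nn(-c3cccc(NC(=O)Nc4cc(C(F)(F)F)cc(C(F)(F)F)c4)c3)cc2-c2ccncc2)ccc1Cl` gives 933 nM, and compound 3 `COc1cc(-c2nn(-c3cccc(NC(=O)c4cccc(C(F)(F)F)c4)c3)cc2-c2ccncc2)ccc1Cl` gives 1430 nM. Compound 3 carries the highest of the three numbers, but its gaps to compound 1 and to compound 2 both lie within the scatter, so the three cannot be ranked. Compound 4 `COc1cc(-c2nn(-c3cccc(NC(=O)c4ccc(Cl)c(C(F)(F)F)c4)c3)cc2-c2ccncc2)ccc1Cl` differs from compound 3 by chloro in place of hydrogen on an aromatic carbon. Among the measured compounds shown here, no measured pair shows this change, so no step beyond the scatter is expected in this assay, with a slight lean toward a lower number. The estimated step from compound 3 to compound 4 is a 1.3-fold lower number from compound 3 to compound 4 (0.11 log units; within the scatter). Compound 4 is expected to give 1100 nM, between 500 nM and 2500 nM.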

Compound 4, concentration for 50% growth inhibition: 2240 nM
Beside the measured number, compound 4's estimate is 2.0-fold (0.31 log units) below it, within the range that was stated.
By their numbers in this assay, from the lowest: compounds 2, 1, 3 and 4 (each within the scatter of the next, the first and the last beyond it).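

In this assay, chloro on the aromatic carbon ortho to the trifluoromethyl group and para to a large group gives a 1.6-fold higher number from compound 3 to compound 4 (0.19 log units; within the scatter), the first one-place pair among these compounds, so this position takes chloro with no step beyond the scatter. No separate measurement bears on this result. The compounds shown leave open whether an amine or a carboxylic acid at this carbon would give a step beyond the scatter, and whether chloro here would read the same on the urea arm of compound 2.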